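Lengthening the Para Group: From Allyl to Phenyl

The source may report more compounds than this note shows. Statements on the series, on what has been measured and on what is new or still open speak of the compounds shown alone.

Measured in a functional assay (brain) with Rattus norvegicus as the target; a higher number here means a weaker inhibitor, a lower number a stronger inhibitor:
Compound 1 `C=Cc1ccc([C@H]2CCN(C)C[C@H]2C(=O)OC)cc1`: 155 nM
Compound 2 `C=CCc1ccc([C@H]2CCN(C)C[C@H]2C(=O)OC)cc1`: 334 nM

Of the two measured compounds, compound 2 has the higher number, 334 nM, and so is the weaker inhibitor. Compound 3 `COC(=O)[C@@H]1CN(C)CC[C@@H]1c1ccc(-c2ccccc2)cc1` keeps the shared core but has phenyl in place of allyl on an aromatic carbon, para to a large group (phenyl in place of allyl on an aromatic carbon). Going by the values given here, only one measured step bears on this position: a modest rise, a 2.2-fold higher number from compound 1 to compound 2 (0.33 log units; beyond the scatter), when allyl replaced vinyl. With that single step as a guide, phenyl, the bigger group, is expected to raise the number again in this assay. The expected change is a 2.4-fold higher number from compound 2 to compound 3 (0.38 log units; beyond the scatter). The estimate for compound 3 is 800 nM, with an expected range of 220 nM to 3000 nM.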

Compound 3, half-maximal inhibitory concentration: 67 nM
The estimate for compound 3 lay 12-fold (1.08 log units) above the measured number, outside the stated range (below it).
By their numbers in this assay, from the lowest: compound 3; then compound 1; then compound 2.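

In this assay, phenyl on this aromatic carbon gives a 5.0-fold lower number from compound 2 to compound 3 (0.70 log units; beyond the scatter) and a 2.3-fold lower number from compound 1 to compound 3 (0.36 log units; beyond the scatter), so the rise seen with allyl in place of vinyl does not carry on to phenyl. A larger group here therefore need not mean a higher number, since phenyl has more heavy atoms than allyl. Nothing available explains this reversal. Going by these compounds, whether an aromatic ring is what matters remains open, since a saturated cyclohexyl ring or a longer butyl chain could separate ring type from size. An amine on the phenyl ring is another open case.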